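Chlorophenyl ethers: the step from compound 3 to compound 4

A few compounds are considered here, and "the series" means these few. Any claim that something is new, unique, unknown or untested is made for them only; others in the source may bear on it.

In a functional assay on A549 cells (Homo sapiens) for antiproliferative activity, read by MTT assay, with a stated time of 72 h (on this read-out lower numbers stand for stronger inhibition and higher numbers for weaker inhibition), compound 1 `NC1=NC2(CCOCC2)N(OCCCOc2ccccc2)C(N)=N1` gives 1080 nM, compound 2 `NC1=NC2(CCOCC2)N(OCCCOc2ccc(Cl)c(Cl)c2)C(N)=N1` gives 790 nM and compound 3 `NC1=NC2(CCOCC2)N(OCCCOc2cc(Cl)c(Cl)cc2Cl)C(N)=N1` gives 680 nM. Compound 3 holds the lowest of these three numbers, but it stays within the scatter of both others. Compound 4 `NC1=NC2(CCOCC2)N(OCCCOc2cccc(Cl)c2)C(N)=N1` differs from compound 3 by 3-chlorophenyl in place of 2,4,5-trichlorophenyl on an oxygen on a saturated carbon, with 3-chlorophenyl in place of 2,4,5-trichlorophenyl on an oxygen on a saturated carbon. For the measured compounds named here, three measured steps bear on this change: a 1.4-fold lower number from compound 1 to compound 2 (0.14 log units; within the scatter), a 1.2-fold lower number from compound 2 to compound 3 (0.07 log units; within the scatter) and a 1.6-fold lower number from compound 1 to compound 3 (0.20 log units; within the scatter). All three stay within the scatter, so no shift beyond it is expected in this assay. The expected step is a 1.3-fold higher number from compound 3 to compound 4 (0.12 log units; within the scatter). For compound 4 the estimated value is 900 nM, within a range of 550 nM to 1500 nM.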

Compound 4, half-maximal inhibitory concentration: 150 nM
The estimate for compound 4 lay 6.0-fold (0.78 log units) above the measured number; measured number outside the range, below it.
By their numbers in this assay, from the lowest: compound 4; then compounds 3, 2 and 1 (each within the scatter of the next).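

In this assay, the 3-chlorophenyl ether on this saturated chain separates from the other aryl ethers: a 4.5-fold lower number from compound 3 to compound 4 (0.66 log units; beyond the scatter), a 5.3-fold lower number from compound 2 to compound 4 (0.72 log units; beyond the scatter) and a 7.2-fold lower number from compound 1 to compound 4 (0.86 log units; beyond the scatter). Chloro in place of hydrogen has no single effect at this position: the same change on two cores in this assay, a 1.2-fold lower number (0.07 log units; within the scatter) from compound 2 to compound 3 and a 7.2-fold lower number (0.86 log units; beyond the scatter) from compound 1 to compound 4, 6.2-fold (0.79 log units) apart, beyond the scatter of two such steps. Chlorine count alone does not order these compounds, as compound 2 and compound 3 carry more chlorine than compound 4 but remain within the scatter of compound 1.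

As far as these compounds go, what remains open is whether a bromo, fluoro or methoxy group in place of the chloro of compound 4 would give a similar number. From the compounds shown here alone, the effect of a longer chain carrying the 3-chlorophenyl ether also remains open.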